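The compounds below may be only part of what the source reports. "The series", "measured", "known", "first", "only" and "open" are said of these compounds alone.

Working notes on the series.

Compound 1 `Cc1ccccc1Cn1cc(COc2ccc3c(=O)ccoc3c2)nn1` sits at a limit of the assay in a functional assay on SW480 cells (Homo sapiens) for cytotoxicity, read by MTT assay, with a stated time of 48 h; on this read-out lower numbers stand for stronger inhibition and higher numbers for weaker inhibition: compound 1 gives > 100000 nM. Among the compounds with values here, compound 2 `O=c1ccoc2cc(OCc3cn(Cc4ccccc4F)nn3)ccc12` is the only compound with a number rather than a limit; in this assay compound 2 gives 11400 nM. Within the data shown here, the one measured step, an at least 8.7-fold lower number from compound 1 to compound 2 (0.94 log units; beyond the scatter), is therefore only a bound on the size of the change, resting on (the limit of > 100000 nM in this assay, at which 1 of the 2 values shown sits).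

Compound 3 `O=c1ccoc2cc(OCc3cn(Cc4ccc([N+](=O)[O-])cc4)nn3)ccc12` differs from compound 2 by 4-nitrophenyl in place of 2-fluorophenyl on a saturated chain carbon bound to an aromatic nitrogen. The measured step from compound 1 to compound 2 bears on it only loosely: it also altered the aryl group at that place, but by a different substituent at a different position of the ring, and its size is known only as a bound. Among the measured compounds shown here, no directly comparable step exists. The expectation for compound 3 is thus a step of a 1.3-fold higher number from compound 2 to compound 3 (0.12 log units; within the scatter), not beyond the scatter, with a wide range. Compound 3 is estimated at 15000 nM, between 4000 nM and 60000 nM.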

Compound 3, half-maximal inhibitory concentration: 19300 nM
For compound 3 the middle estimate is 1.3-fold (0.11 log units) below the measured one; the measured number falls inside the stated range.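

In this assay, within the data shown here, 4-nitrophenyl in place of 2-fluorophenyl on a saturated chain carbon bound to an aromatic nitrogen gives a 1.7-fold higher number from compound 2 to compound 3 (0.23 log units; within the scatter), so two aryl groups that differ in both substituent and ring position cannot be told apart at this place, which the single earlier step could not show. The second step from the 2-methylphenyl group, an at least 5.1-fold lower number from compound 1 to compound 3 (0.71 log units; beyond the scatter), runs the same way as the first and sets that group apart from both others in the series, though its size is again only a bound: the limit of > 100000 nM in this assay, at which 1 of the 3 values shown sits. In this assay compound 1 gives > 100000 nM, which is a limit and not a number.

Open, going by these compounds, is how an unsubstituted phenyl, or an aryl ring carrying an amine or a carboxylic acid, would read at this place, and so whether any substituent on this ring matters beyond the contrast with 2-methylphenyl. Also open, on these data alone, is whether a longer chain in place of the saturated chain carbon would shift the number, and whether the same order would hold in another cell line.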